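The source may hold more compounds than are shown below. What is called first, only, known or untested is meant among the compounds shown, and "the series" means these compounds.

In a functional assay on HeLa cells (Homo sapiens) for inhibition, read by MTT assay, with a stated time of 48 h (a higher number here means a weaker inhibitor, a lower number a stronger inhibitor), compound 3 (`Cc1c(NC(=O)CN2C(=O)S/C(=C\c3ccc([N+](=O)[O-])cc3)C2=O)c(=O)n(-c2ccccc2)n1C`) gives 77200 nM and lies within the scatter of compound 2 (`COc1ccc(/C=C2\SC(=O)N(CC(=O)Nc3c(C)n(C)n(-c4ccccc4)c3=O)C2=O)cc1`) at 64800 nM in this small set. Compound 1 (`COc1cc(/C=C2\SC(=O)N(CCNC(=O)Nc3c(C)n(C)n(-c4ccccc4)c3=O)C2=O)cc(OC)c1OC`) gives 15800 nM as a clearly lower number than compound 3, but it differs from compound 3 in more than one place.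

Compound 4 (`Cc1c(NC(=O)CN2C(=O)S/C(=C\c3ccc(Cl)cc3)C2=O)c(=O)n(-c2ccccc2)n1C`) keeps all of compound 3 except one group, going from 4-nitrophenyl to 4-chlorophenyl, with chloro in place of nitro on an aromatic carbon. Among the compounds with values here, one measured step bears on this, nitro in place of methoxy on an aromatic carbon, and it shows a 1.2-fold higher number from compound 2 to compound 3 (0.08 log units; within the scatter) as its whole size. Within the data shown here, no measured compound carries chloro, so that single step is only a thin guide. On this evidence, no shift beyond the scatter is expected in this assay and the expected size is a 1.1-fold lower number from compound 3 to compound 4 (0.04 log units; within the scatter) with no firm direction. The estimated value for compound 4 is 70000 nM (expected range 35000 nM to 130000 nM).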

Compound 4, half-maximal inhibitory concentration: 20000 nM
The estimate for compound 4 lay 3.5-fold (0.54 log units) above the measured number; the whole stated range lies above it.
By their numbers in this assay, from the lowest: compounds 1 and 4 (each within the scatter of the next); then compounds 2 and 3 (each within the scatter of the next).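

In this assay, the group at this position, para to a large group on the six-membered aromatic ring, can clearly change the result, even though the earlier swap of methoxy for nitro stayed within the scatter. Chloro in place of nitro gives a 3.9-fold lower number from compound 3 to compound 4 (0.59 log units; beyond the scatter), and chloro in place of methoxy gives a 3.2-fold lower number from compound 2 to compound 4 (0.51 log units; beyond the scatter), so on this shared core chloro stands apart from both earlier groups, though both steps are modest. No measurement here accounts for that difference.

Going by these compounds, it remains open whether this lower number is particular to chloro or would also appear with other groups at this position, such as fluoro, bromo or an amine. It is also unknown whether chloro would give a similar step on the different chain of compound 1.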